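The compounds below may be only part of what the source reports. "The series", "measured", "known", "first", "only" and "open" are said of these compounds alone.

Three compounds share one core, an azo-linked indole joined to a benzamide, and differ only in what sits on the ring of the anilide. Compound 1 `O=C(Nc1ccccc1)c1ccc(/N=N\c2c[nH]c3ccccc23)cc1` carries nothing there; in a functional assay on HCT-116 cells (Homo sapiens) for inhibition, read by MTT assay, with a stated time of 72 h (on this read-out lower numbers stand for stronger inhibition and higher numbers for weaker inhibition), compound 1 gives 103000 nM. Compound 2 `O=C(Nc1cccc(Cl)c1)c1ccc(/N=N\c2c[nH]c3ccccc23)cc1` carries a chloro, and in this assay compound 2 gives 80000 nM. Compound 3 `Cc1cccc(NC(=O)c2ccc(/N=N\c3c[nH]c4ccccc34)cc2)c1` carries a methyl, and in this assay compound 3 gives 98900 nM. All three numbers lie close together: the steps of a 1.3-fold lower number from compound 1 to compound 2 (0.11 log units; within the scatter), a 1.0-fold lower number from compound 1 to compound 3 (0.02 log units; within the scatter) and a 1.2-fold higher number from compound 2 to compound 3 (0.09 log units; within the scatter) are each within the scatter, so compound 3 cannot be set apart from compound 1 or compound 2 on these numbers.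

Compound 4 `O=C(Nc1cccc([N+](=O)[O-])c1)c1ccc(/N=N\c2c[nH]c3ccccc23)cc1` is the next member. Relative to compound 3 the change is nitro in place of methyl on an aromatic carbon. Going by the values given here, the only steps that bear on this are the three ring-substituent swaps above, and none of them moved the number beyond the scatter, whether a hydrogen, a chloro or a methyl occupied the position. A nitro at the same place is therefore expected to behave alike, giving an estimated step of a 1.1-fold lower number from compound 3 to compound 4 (0.04 log units; within the scatter) in this assay, with no direction beyond the scatter. For compound 4 the expected value in this assay is 90000 nM, with a range from 40000 nM to 200000 nM.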

Compound 4, half-maximal inhibitory concentration: 70100 nM
Estimate against measurement, compound 4: 1.3-fold (0.11 log units) above, within the range that was stated.
By their numbers in this assay, from the lowest: compounds 4, 2, 3 and 1 (each within the scatter of the next).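

The nitro group enters with 3 heavy atoms and 2 hydrogen-bond acceptors, where the methyl has 1 heavy atom and no acceptor, yet in this assay the swap gives only a small step (a 1.4-fold lower number from compound 3 to compound 4 (0.15 log units; within the scatter)), and the steps from the other two groups are just as small (a 1.1-fold lower number from compound 2 to compound 4 (0.06 log units; within the scatter); a 1.5-fold lower number from compound 1 to compound 4 (0.17 log units; within the scatter)), all of them within the scatter. Hydrogen, chloro, methyl and nitro have now all been compared at this one place, so the insensitivity seen among the first three compounds also holds for a group with more atoms and with hydrogen-bond acceptors, though only for these four compounds. Nothing available here explains why the number stays so flat at this position.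

From the compounds shown here alone, whether any group at this position can move the number beyond the scatter remains open, for instance an amine or a carboxylic acid, or a longer chain such as butyl. Also open, going by these compounds, is whether hydrogen, chloro, methyl and nitro would behave alike at another place on the same ring.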